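The source may hold more compounds than are shown below. What is called first, only, known or untested is meant among the compounds shown, and "the series" means these compounds.

Compound 3, `Cc1ccc(NN=C2CCC(C)n3c2ncc(C(=O)O)c3=O)cc1C`, is known in a functional assay on the whole organism with Rattus norvegicus as the target (on this read-out higher numbers stand for an effect only at larger amounts of compound and lower numbers for an effect already at smaller amounts), only as a limit: in this assay compound 3 gives > 100 umol/kg, which is a limit of the assay rather than a number. Compound 2, `Cc1cccc(NN=C2CCC(C)n3c2ncc(C(=O)O)c3=O)c1C`, sits at the same kind of limit, and in this assay compound 2 gives > 100 umol/kg. Compound 1, `CC1CCC(=NNc2ccccc2)c2ncc(C(=O)O)c(=O)n21`, carries a plain phenyl on the amine nitrogen, and in this assay compound 1 gives 1.2 umol/kg. Replacing that phenyl by 2,3-dimethylphenyl gave an at least 83-fold higher number from compound 1 to compound 2 (1.92 log units; beyond the scatter), and replacing it by 3,4-dimethylphenyl gave an at least 83-fold higher number from compound 1 to compound 3 (1.92 log units; beyond the scatter); between the two limits the step is a step that the two limits leave unreadable from compound 2 to compound 3. Compound 4, `Cc1cccc(C)c1NN=C1CCC(C)n2c1ncc(C(=O)O)c2=O`, differs from compound 3 as follows: 2,6-dimethylphenyl in place of 3,4-dimethylphenyl on an amine nitrogen. Both patterns of two methyl groups measured so far reached (the limit of > 100 umol/kg in this assay, at which 2 of the 3 values shown sit), so compound 4 is expected to behave alike, with a step that the limit leaves unreadable from compound 3 to compound 4 that is itself not readable against a limit. Compound 4 is therefore estimated at 150 umol/kg, within a range from 30 umol/kg to 1000 umol/kg, and is most likely to come back as a limit once more.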

Compound 4, dose for 50% inhibition: 320 umol/kg
For compound 4 the middle estimate is 2.1-fold (0.33 log units) below the measured one, and the stated range covers the measured number.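

With 2,6-dimethylphenyl on the amine nitrogen, the cost of adding two methyl groups to the plain phenyl finally has a size in this assay: 2,6-dimethylphenyl in place of phenyl gives a 270-fold higher number from compound 1 to compound 4 (2.43 log units; beyond the scatter). All three patterns of two methyl groups shown now sit far from the plain phenyl of compound 1, and no compound shown goes against this. The steps linking compound 4 to compound 2 and compound 3 cannot be read, and the three patterns cannot be put in order, because those two compounds are known only as limits: the limit of > 100 umol/kg in this assay, at which 2 of the 4 values shown sit.

As far as these compounds go, whether a single methyl group on the phenyl already brings a rise of this size stays open. So does the effect of a chlorine or a methoxy group on that ring.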